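The source may report more compounds than this note shows. Statements on the series, on what has been measured and on what is new or still open speak of the compounds shown alone.

Measured in a physicochemical assay for solubility, read by HPLC, using the shake flask method, measured as kinetic solubility, with a stated time of 20 h, at pH 6.5, tested at 200 uM; on this read-out higher numbers stand for higher solubility and lower numbers for lower solubility:
- Compound 1 `NS(=O)(=O)c1cccc(-c2ccc3nccc(-c4ccncc4)c3n2)c1`: < 5000 nM, a limit of the assay
- Compound 2 `CN1CCN(c2ccnc3ccc(-c4cccc(S(N)(=O)=O)c4)nc23)CC1`: 200000 nM

Among the measured compounds shown here, compound 2 holds the only actual number here, 200000 nM. The entry for compound 1 is a limit, and compound 1 sits at the limit of < 5000 nM in this assay, at which 1 of the 2 values shown sits.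

Compound 3 `NS(=O)(=O)c1cccc(-c2ccc3nccc(-c4cccnc4)c3n2)c1` has pyridin-3-yl in place of the 4-methylpiperazin-1-yl of compound 2, on an aromatic carbon opposite the ring nitrogen (pyridin-3-yl in place of 4-methylpiperazin-1-yl on an aromatic carbon). For the measured compounds named here, one measured step bears on this change. Putting 4-methylpiperazin-1-yl in place of pyridin-4-yl gave an at least 40-fold higher number from compound 1 to compound 2 (1.60 log units; beyond the scatter), a large step beyond the scatter. Read in reverse for a pyridinyl group entering, that step points to an expected large fall, a 50-fold lower number from compound 2 to compound 3 (1.70 log units; beyond the scatter). The estimate for compound 3 is 4000 nM, with an expected range of 1000 nM to 15000 nM.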

Compound 3, solubility: < 5000 nM
Compound 3 ended at the assay's limit (the forecaster's own chance of this, stated with the estimate: 65%); the middle value does not contradict the limit.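

In this assay, pyridin-3-yl in place of 4-methylpiperazin-1-yl on this aromatic carbon, opposite the ring nitrogen, gave an at least 40-fold lower number from compound 2 to compound 3 (1.60 log units; beyond the scatter). The large gap to compound 2 is therefore not confined to pyridin-4-yl, as a second pyridinyl group at this place also leaves the compound at the limit: the limit of < 5000 nM in this assay, at which 2 of the 3 values shown sit. The step from compound 1 to compound 3 cannot be read, as the entries for both compounds are limits, so the two pyridinyl groups cannot be ranked.

Going by these compounds, how far the true values of these two compounds lie under the limit remains open. Also open, on these data alone, is whether another amine at this place, such as morpholine or an open-chain dimethylamino group, would come close to compound 2 at 200000 nM.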